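Swapping Methoxymethoxy for (((Tert-butyl)carbonyl)oxy)methyl at the Aromatic Carbon

This account rests on a few compounds, and the source may have more. Where it says the series, first, only, none or still open, it means among the compounds named here.

Measured in a functional assay for inhibition of Vanilloid receptor (Rattus norvegicus); on this read-out lower numbers stand for stronger inhibition and higher numbers for weaker inhibition:
Compound 1, `CC(C)Oc1cc(C(C)(C)C)ccc1C/N=C(\S)NCc1ccc(NS(C)(=O)=O)cc1`: compound 1 gives 350 nM
Compound 2, `COCOc1cc(C(C)(C)C)ccc1C/N=C(\S)NCc1ccc(NS(C)(=O)=O)cc1`: compound 2 gives 500 nM

Within the data shown here, compound 2 holds the highest of the two numbers so far, and the only step that leads to it is a 1.4-fold higher number from compound 1 to compound 2 (0.15 log units; within the scatter). That step exchanged one group for another on the same oxygen and moved the number by less than the scatter. Compound 3, `CC(C)(C)C(=O)OCc1cc(C(C)(C)C)ccc1C/N=C(\S)NCc1ccc(NS(C)(=O)=O)cc1`, goes further: (((tert-butyl)carbonyl)oxy)methyl in place of methoxymethoxy on an aromatic carbon. Among the measured compounds shown here, no measured step replaces an oxygen-linked group by a carbon-linked one, so the single measured step gives only weak guidance. For the measured compounds named here, on that basis compound 3 is expected to stay close to compound 2, with the estimated step of a 1.2-fold higher number from compound 2 to compound 3 (0.08 log units; within the scatter) lying within the scatter but carrying a wide range because the one relevant precedent is a 1.4-fold higher number from compound 1 to compound 2 (0.15 log units; within the scatter). The estimate for compound 3 in this assay is 600 nM, between 200 nM and 2000 nM.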

Compound 3, half-maximal inhibitory concentration: 70 nM
Compound 3: the middle estimate sits 8.6-fold (0.93 log units) above what was measured; measured number outside the range, below it.
By their numbers in this assay, from the lowest: compound 3; then compounds 1 and 2 (each within the scatter of the next).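

In this assay, this aromatic carbon, meta to a tert-butyl group, turns out to respond beyond the scatter, which the exchange on the oxygen between isopropoxy and methoxymethoxy did not show. Putting (((tert-butyl)carbonyl)oxy)methyl in place of methoxymethoxy gives a 7.1-fold lower number from compound 2 to compound 3 (0.85 log units; beyond the scatter) and, set against isopropoxy, the same group gives a 5.0-fold lower number from compound 1 to compound 3 (0.70 log units; beyond the scatter) so the new group stands apart from both earlier ones. No measurement at hand explains this gain.

The change replaces an oxygen-linked group of 4 heavy atoms with a carbon-linked one of 8, so the compounds shown do not separate the link from the rest of the group. From the compounds shown here alone, whether a plain hydroxymethyl or a longer alkyl chain on this carbon would keep the lower number stays open.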